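Shifting the attachment of the ethenyl group in compound 3

The compounds below may be only part of what the source reports. "The series", "measured", "known", "first", "only" and "open" are said of these compounds alone.

Measured in a functional assay on HeLa cells (Homo sapiens) for cytotoxicity, read by MTT assay, with a stated time of 48 h; a lower number here means a stronger inhibitor, a higher number a weaker inhibitor:
- Compound 1 `COc1ccc(/C=C/c2cc(OC)c(OC)c(OC)c2-c2ccc(OC)cc2)cc1`: 19000 nM
- Compound 2 `COc1ccc(/C=C/c2cc(OC)c(OC)c(OC)c2-c2ccccc2)cc1`: 26000 nM
- Compound 3 `COc1cc(/C=C/c2ccc(C)cc2)c(-c2ccccc2)c(OC)c1OC`: 45000 nM

Compound 3 stays within the scatter of compound 2, and its number is higher than that of compound 1, a gap beyond the scatter. Compound 4 `C=C(c1ccc(C)cc1)c1cc(OC)c(OC)c(OC)c1-c1ccccc1` has the same atoms as compound 3, joined differently: 1-(4-methylphenyl)ethenyl in place of 2-(4-methylphenyl)ethenyl on an aromatic carbon. Neither a 1.4-fold higher number from compound 1 to compound 2 (0.14 log units; within the scatter) nor a 1.7-fold higher number from compound 2 to compound 3 (0.24 log units; within the scatter) touches this attachment, and both stayed within the scatter, so no step beyond the scatter is expected in this assay, with wide uncertainty. The expected step is a 1.1-fold lower number from compound 3 to compound 4 (0.05 log units; within the scatter). The estimate for compound 4 is 40000 nM, with an expected range of 15000 nM to 100000 nM.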

Compound 4, half-maximal inhibitory concentration: 28000 nM
Compound 4: the middle estimate sits 1.4-fold (0.15 log units) above what was measured; the range from low to high includes it.
By their numbers in this assay, from the lowest: compounds 1, 2, 4 and 3 (each within the scatter of the next, the first and the last beyond it).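

In this assay, 1-(4-methylphenyl)ethenyl in place of 2-(4-methylphenyl)ethenyl gives a 1.6-fold lower number from compound 3 to compound 4 (0.21 log units; within the scatter) and so stays within the scatter. The earlier steps shown here changed only a methoxy group, whereas this one shows that rejoining the link itself, at the aromatic carbon ortho to a phenyl group, also produces no step beyond the scatter. Nothing available explains this result. As far as these compounds go, it remains open whether the 1-substituted ethenyl attachment would stay within the scatter with an amine or a carboxylic acid in place of the methyl group on its ring.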